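The source may report more compounds than this note shows. Statements on the series, on what has been measured and on what is new or still open speak of the compounds shown alone.

Measured so far:
Compound 1 `Cc1cc(C(=O)O)ccc1OCCCCOc1ccc(C(=O)CC(C)C)c(O)c1C` gives 1850 nM in an assay on HEK293 cells for positive allosteric modulation of metabotropic glutamate receptor 3 (Rattus norvegicus), read by thallium flux, with a stated time of 2.5 min; a higher number here means that more compound is needed for the effect, a lower number that less compound is needed.
Compound 2 `Cc1c(OCCCCOc2ccc(C(=O)O)cc2Cl)ccc(C(=O)CC(C)C)c1O` gives 1140 nM in this assay.

Among the measured compounds shown here, compound 2 has the lower of the two numbers, but the sole step, a 1.6-fold lower number from compound 1 to compound 2 (0.21 log units; within the scatter), lies within the scatter, so compound 2 and compound 1 cannot be ranked. Compound 3 `Cc1c(OCCCCOc2cccc(C(=O)O)c2)ccc(C(=O)CC(C)C)c1O` differs from compound 2 by 3-carboxyphenyl in place of 4-carboxy-2-chlorophenyl on an oxygen on a saturated carbon. For the measured compounds named here, no measured step covers this change, and the one known step bears only on the chloro, so no direction beyond the scatter is expected in this assay. Compound 3 is estimated at 2000 nM, within 700 nM to 6000 nM. This estimate means an expected step of a 1.8-fold higher number from compound 2 to compound 3 (0.24 log units; within the scatter).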

Compound 3, half-maximal effective concentration: 1430 nM
Compound 3: middle estimate off by 1.4-fold (0.15 log units), on the high side; the range from low to high includes it.
By their numbers in this assay, from the lowest: compounds 2, 3 and 1 (each within the scatter of the next).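

With 3-carboxyphenyl on an oxygen on a saturated carbon, the change from 4-carboxy-2-chlorophenyl gives a 1.3-fold higher number from compound 2 to compound 3 (0.10 log units; within the scatter) and the change from 4-carboxy-2-methylphenyl gives a 1.3-fold lower number from compound 1 to compound 3 (0.11 log units; within the scatter) in this assay for this place. Compound 3 carries neither the chloro nor the methyl, yet it cannot be told apart from compound 1 or compound 2, so neither group is shown to matter in these compounds. Going by these compounds, whether an amide in place of the carboxylic acid, or a longer chain in place of the saturated chain, would give a step beyond the scatter stays open. Nothing available explains why these three compounds cannot be separated.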